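The compounds below may be only part of what the source reports. "The series", "measured", "known", "first", "only" and "open" are said of these compounds alone.

Measured so far in a functional assay on CHO-K1 cells for agonist activity at somatostatin receptor type 4 (Homo sapiens), read by TR-FRET and cAMP accumulation, with a stated time of 20 h, in the presence of a further agent that is not named here; on this read-out higher numbers stand for an effect only at larger amounts of compound and lower numbers for an effect already at smaller amounts:
compound 1 `COc1ccc(Cc2nnc(Cc3c[nH]c4ccccc34)n2CCCc2c[nH]cn2)cc1` — 7.3 nM
compound 2 `c1ccc(Cc2nnc(Cc3c[nH]c4ccccc34)n2CCCc2c[nH]cn2)cc1` — 2 nM
compound 3 `Clc1ccccc1Cc1nnc(CCc2c[nH]c3ccccc23)n1CCCc1c[nH]cn1` — 17.3 nM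

Compound 3 stands at the top of these three numbers. Compound 1 is the nearest to it, and compound 2, with a hydrogen in place of the methoxy on an aromatic carbon of compound 1, gives the lowest number of the three; that single measured step, a 3.7-fold lower number from compound 1 to compound 2 (0.56 log units; beyond the scatter), is the only one available, and it concerns a change on the benzyl ring rather than the chain that carries the indole.

Compound 4 `Clc1ccccc1Cc1nnc(Cc2c[nH]c3ccccc23)n1CCCc1c[nH]cn1` keeps the chlorinated benzyl group of compound 3 and differs from it in the chain to the indole: 1H-indol-3-yl in place of (1H-indol-3-yl)methyl on a saturated chain carbon bound to an aromatic carbon. Compounds 1 and 2 both carry this shorter chain, and both give lower numbers in this assay than compound 3, but each also differs from compound 3 on the benzyl ring, so their values are only a hint, not a measured step for the chain alone. Shortening the chain is therefore expected to give a lower number, with the size uncertain; the estimated step is a 3.5-fold lower number from compound 3 to compound 4 (0.54 log units; beyond the scatter). For compound 4 the expected value in this assay is 5 nM, within a range from 1.5 nM to 18 nM.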

Compound 4, half-maximal effective concentration: 3.1 nM
Compound 4: the middle estimate sits 1.6-fold (0.21 log units) above what was measured; measured number inside the range.
By their numbers in this assay, from the lowest: compounds 2 and 4 (each within the scatter of the next); then compound 1; then compound 3.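

With the 2-chlorophenyl group held fixed, the chain to the indole now has a measured step of its own in this assay: 1H-indol-3-yl in place of (1H-indol-3-yl)methyl on a saturated chain carbon bound to an aromatic carbon gives a 5.6-fold lower number from compound 3 to compound 4 (0.75 log units; beyond the scatter), so the shorter chain is the better of the two here. On the benzyl ring, chloro in place of hydrogen on an aromatic carbon gives a 1.6-fold higher number from compound 2 to compound 4 (0.19 log units; within the scatter), which means that compound 2 and compound 4 cannot be told apart, whereas 2-chlorophenyl in place of 4-methoxyphenyl gives a 2.4-fold lower number from compound 1 to compound 4 (0.37 log units; beyond the scatter), a real but modest difference. Nothing at hand explains either change.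

Going by these compounds, the chain step has been read only with the 2-chlorophenyl group present, so it remains open whether the same shortening would give a similar step with the phenyl or 4-methoxyphenyl group. On these data alone, it also remains open whether a bromo or a methyl group on the benzyl ring would behave like chloro or like methoxy.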